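The compounds below may be only part of what the source reports. "The series", "measured", "known", "first", "only" and "open" are said of these compounds alone.

- compound 1 `COc1ccccc1S(=O)(=O)/C=C/c1ccccn1`: 91%
- compound 2 `COc1ccccc1S(=O)(=O)/C=C/c1ccc(Cl)cn1`: "not determined" (no result reported)
- compound 3 `COc1ccccc1S(=O)(=O)/C=C/c1ncccc1Cl`: "not determined" (no result reported)
- compound 4 `COc1ccccc1S(=O)(=O)/C=C/c1cccnc1`: not yet measured

In an ADME assay on microsomes from liver (Homo sapiens) for metabolic stability, read by LC-MS, using NADPH, with stated times of 5 min and 30 min, tested at 1 uM (on this read-out lower numbers stand for a less stable compound and higher numbers for a more stable compound), compound 1 gives 91%. Among the compounds with values here, this is the only number, so compound 1 cannot be ranked against any other compound.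

The change to compound 4 is pyridin-3-yl in place of pyridin-2-yl on a double-bonded chain carbon bound to a double-bonded chain carbon.

Within the data shown here, no measured pair shows the size of any step in this assay. With compound 1 at 91%, little room remains upward, so a modest downward step is expected, possibly none beyond the scatter. The expected step is a number 9 percentage points lower from compound 1 to compound 4 (within the scatter). For compound 4 the estimated value is 82%, with an expected range of 60% to 96%.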

Compound 4, percent of the compound remaining: 97%
Compound 4: the middle estimate sits 15 percentage points below what was measured, and the stated range ends below it.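

In this assay, within the data shown here, the first readable step at this place, pyridin-3-yl in place of pyridin-2-yl on a double-bonded chain carbon bound to a double-bonded chain carbon, comes out as a number 6 percentage points higher from compound 1 to compound 4 (within the scatter). Pyridin-2-yl and pyridin-3-yl therefore cannot be told apart on this read-out. Nothing at hand offers a reason for this result.

The steps to compound 2 and compound 3 cannot be read, as neither has a number. Going by these compounds, whether a different group at this place, such as a carboxylic acid or an amine, would move the read-out beyond the scatter remains open.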